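The source may hold more compounds than are shown below. What is called first, only, known or untested is meant among the compounds shown, and "the series" means these compounds.

The measured compounds and their numbers:

- compound 1, `COc1cc(C)cc(-c2c(-c3ccnc(-c4ccc(C(C)=O)cc4)c3)cnn2CC#N)c1`: 47%
- compound 2, `Cc1cc(O)cc(-c2nn(CC#N)cc2-c2ccnc(-c3ccc(Oc4ccccc4)cc3)c2)c1`: 46%
- compound 3, `COc1cc(C)cc(-c2nn(CC#N)cc2-c2ccnc(-c3ccc(N(C)C)cc3)c2)c1`: 10%

In a functional assay on K562 cells (Homo sapiens) for cytotoxicity, read by sulforhodamine B assay, with a stated time of 48 h, tested at 100 nM (on this read-out lower numbers stand for a stronger effect and higher numbers for a weaker effect at the one concentration tested), compound 1 gives 47%, the highest of the three numbers, which on this read-out means the weakest effect of the set. Compound 2 gives 46%, a number within the scatter of compound 1, so the two cannot be told apart. Compound 3 gives 10%, far lower than compound 1 and well beyond the scatter, so its effect is clearly stronger.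

Compound 4, `COc1cc(C)cc(-c2c(-c3ccnc(-c4ccc(N(C)C)cc4)c3)cnn2CC#N)c1`, has not yet been measured. It keeps the whole of compound 1 except in one place: dimethylamino in place of acetyl on an aromatic carbon. Within the data shown here, compound 3 carries the same dimethylamino group on a core that is arranged differently, and no step between compound 1 and compound 3 is given, so its low number is only a hint, not a measured step.

Resting on that hint, the step from compound 1 to compound 4 is expected to run toward a lower number, that is a stronger effect, by a number 22 percentage points lower from compound 1 to compound 4 (beyond the scatter). Compound 4 is therefore estimated at 25%, within a range from 8% to 48%.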

Compound 4, a percentage reported as activity, at one concentration (the size of the read-out at that concentration, not a potency): 7%
Compound 4: the middle estimate sits 18 percentage points above what was measured; measured number below the stated range.
By their numbers in this assay, from the lowest: compounds 4 and 3 (each within the scatter of the next); then compounds 2 and 1 (each within the scatter of the next).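

Among these compounds, until now no two measured compounds differed in one place, so no single group could be judged on its own. Replacing 4-acetylphenyl with 4-(dimethylamino)phenyl now gives a direct reading in this assay (a number 40 percentage points lower from compound 1 to compound 4 (beyond the scatter)), and on this read-out that large step means a stronger effect. Acetyl and dimethylamino have the same count of heavy atoms, and each has one hydrogen-bond acceptor and no donor, so these counts do not separate them, yet the choice of group at this aromatic carbon clearly matters; no measurement here explains the step.

The compounds shown leave open whether the step depends on the dimethylamino group as a whole or would also appear with a simpler primary amine or a ring amine such as morpholine on the same carbon. They also leave open how far this single step carries over to other versions of the core, and how it would look across a range of concentrations rather than at the one tested.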